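Small Changes on a Pendant Ring, Small Effects So Far

This account rests on a few compounds, and the source may have more. Where it says the series, first, only, none or still open, it means among the compounds named here.

Compound 1, `COc1cc(C(=O)c2sc3ccccc3c2-c2ccccc2)cc(OC)c1OC`: 1700 nM
Compound 2, `COc1cc(C(=O)c2sc3ccccc3c2-c2ccc(C)cc2)cc(OC)c1OC`: 1400 nM
Compound 3, `COc1cc(C(=O)c2sc3ccccc3c2-c2ccc(SC)cc2)cc(OC)c1OC`: 1300 nM

Of the compounds shown here, three have so far been tested in a functional assay on HL-60 cells (Homo sapiens) for antiproliferative activity, read by MTT assay, with a stated time of 72 h; a lower number here means a stronger inhibitor, a higher number a weaker inhibitor. Among the compounds with values here, they share one core and differ only in the single group carried on the pendant phenyl ring. Compound 2, which carries a methyl there, sits close to both of its neighbours: a 1.2-fold lower number from compound 1 to compound 2 (0.08 log units; within the scatter), and a 1.1-fold lower number from compound 2 to compound 3 (0.03 log units; within the scatter). The remaining pair behaves the same way: a 1.3-fold lower number from compound 1 to compound 3 (0.12 log units; within the scatter). None of these three steps reaches beyond the usual scatter of this assay, so the three numbers are best read as one level.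

Compound 4, `COc1ccc(-c2c(C(=O)c3cc(OC)c(OC)c(OC)c3)sc3ccccc23)cc1C`, is the next candidate. Relative to compound 2 the difference is 4-methoxy-3-methylphenyl in place of 4-methylphenyl on an aromatic carbon. Within the data shown here, no measured step matches this exact change. The nearest comparisons are the exchanges of hydrogen for methyl and of methyl for methylsulfanyl on the same ring, and both stayed within the scatter. On that basis no step beyond the scatter is expected in this assay, in either direction.

Compound 4 is therefore estimated at 1300 nM, with a likely range from 600 nM to 3000 nM, which corresponds to an expected step of a 1.1-fold lower number from compound 2 to compound 4 (0.03 log units; within the scatter).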

Compound 4, half-maximal inhibitory concentration: > 10000 nM
Compound 4 gave a limit, no number; the forecaster's own chance of this, stated with the estimate: 3%; middle value at least 7.6-fold (0.88 log units) from the limit.
By their numbers in this assay, from the lowest: compounds 3, 2 and 1 (each within the scatter of the next). At a limit, above all of these: compound 4.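

In this assay compound 4 stands at a limit, not a number: the limit of > 10000 nM in this assay, at which 1 of the 4 values shown sits. Phenyl, 4-methylphenyl and 4-(methylsulfanyl)phenyl at this place, on the aromatic carbon two ring bonds from the ring sulfur, gave steps that all stayed within the scatter, whereas 4-methoxy-3-methylphenyl gives an at least 7.1-fold higher number from compound 2 to compound 4 (0.85 log units; beyond the scatter), along with an at least 7.6-fold higher number from compound 3 to compound 4 (0.88 log units; beyond the scatter) and an at least 5.8-fold higher number from compound 1 to compound 4 (0.76 log units; beyond the scatter). Within the data shown here, these are the first steps beyond the scatter, so the earlier flat picture does not hold for every aromatic ring at this place, and a change confined to the pendant ring can weaken the compound markedly.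

Relative to 4-methylphenyl, the new ring differs in two ways at once, so the compounds shown cannot tell whether the methoxy, the extra methyl or the two together account for the weaker result; a ring carrying only the methoxy or only the extra methyl would separate them. They also leave open how a hydroxyl, an amine or a carboxylic acid on this ring would behave in this assay.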